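The source may report more compounds than this note shows. Statements on the series, on what has been measured and on what is new or still open speak of the compounds shown alone.

Series notes. Compound 1 `Cc1nc2c(c(-c3cc(F)c4c(c3C)CCCO4)c1[C@H](OC(C)(C)C)C(=O)O)CN(CC1CC1c1ccccc1)CC2`, compound 2 `Cc1ccc(CCCN2CCc3nc(C)c([C@H](OC(C)(C)C)C(=O)O)c(-c4cc(F)c5c(c4C)CCCO5)c3C2)cc1F` and compound 3 `Cc1nc2c(c(-c3cc(F)c4c(c3C)CCCO4)c1[C@H](OC(C)(C)C)C(=O)O)CN(CCCc1ccccc1)CC2` share one core and differ only in the group carried on the saturated chain carbon bound to the amine nitrogen in the ring. In an ADME assay on MT2 cells (Homo sapiens) for cytotoxicity, read by XTT assay, with a stated time of 4 days (a higher number here means that more compound is tolerated, a lower number that less compound is tolerated), compound 1 gives > 40000 nM, which is a limit of the assay and not a number. In this assay compound 2 gives > 40000 nM, again a limit. In this assay compound 3 gives > 40000 nM, also a limit. The steps a step that the two limits leave unreadable from compound 1 to compound 2, a step that the two limits leave unreadable from compound 1 to compound 3 and a step that the two limits leave unreadable from compound 2 to compound 3 cannot be read in size, since every value shown sits at the limit of > 40000 nM in this assay, at which 3 of the 3 values shown sit. Compound 3 thus stands at the limit together with the two others, and no ordering among the three is possible.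

Compound 4 `Cc1ccccc1CCCN1CCc2nc(C)c([C@H](OC(C)(C)C)C(=O)O)c(-c3cc(F)c4c(c3C)CCCO4)c2C1` differs from compound 3 by methyl in place of hydrogen on an aromatic carbon. The measured step that comes closest is a step that the two limits leave unreadable from compound 2 to compound 3, which also exchanges substituents on the phenyl of the phenethyl-type chain, yet both of its ends are limits and its size stays unreadable. No readable step exists on which a direction could rest. Compound 4 is expected to remain at the limit in this assay, estimated at 40000 nM within 25000 nM to 60000 nM. The expected step of a number no higher from compound 3 to compound 4 (the limit leaves the size open) is accordingly estimated as none beyond the scatter.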

Compound 4, half-maximal cytotoxic concentration: > 40000 nM
Compound 4: no number, only a limit; the forecaster's own chance of this, stated with the estimate: 85%; the middle value sits exactly at the limit.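

The steps joining compound 4 to compound 1, compound 2 and compound 3 cannot be read in size in this assay, because the values of all these compounds are a limit of the assay and not numbers: the limit of > 40000 nM in this assay, at which 4 of the 4 values shown sit.

The compounds shown leave open where the cytotoxic concentration of each lies, and whether the group on the chain alters it at all.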